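Bromoacrylamide series: methyl in place of ethoxy

The source may report more compounds than this note shows. Statements on the series, on what has been measured and on what is new or still open speak of the compounds shown alone.

Measured so far:
compound 1 `C=C(Br)C(=O)Nc1cccc(-c2cn3nc(Cc4cccc(OC)c4)sc3n2)c1` — 2500 nM
compound 2 `C=C(Br)C(=O)Nc1cccc(-c2cn3nc(-c4ccc(OCC)cc4)sc3n2)c1` — 1100 nM

Both compounds were run in a functional assay on HeLa cells (Homo sapiens) for inhibition, read by cell counting, with a stated time of 4 days; on this read-out higher numbers stand for weaker inhibition and lower numbers for stronger inhibition. Compound 1 gives 2500 nM; compound 2 gives 1100 nM. Going by the values given here, the one step recorded so far, a 2.3-fold lower number from compound 1 to compound 2 (0.36 log units; beyond the scatter), replaces the benzyl-type substituent with a directly attached phenyl ring carrying an ethoxy group. On the numbers shown, compound 2 stands with the lowest value of the two, the nearest being compound 1.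

The next compound, compound 3 `C=C(Br)C(=O)Nc1cccc(-c2cn3nc(-c4ccc(C)cc4)sc3n2)c1`, keeps the core of compound 2 and differs only in that (methyl in place of ethoxy on an aromatic carbon). Among the compounds with values here, no measured step covers this exact exchange: the step from compound 1 to compound 2 alters both the linker and the substituent at once, so it bears on the present change only loosely. Within the data shown here, with no direct precedent, the working assumption is that compound 3 behaves in this assay much like compound 2, and a step of about a 1.4-fold higher number from compound 2 to compound 3 (0.13 log units; within the scatter) is expected, which may well fall within the scatter. On that basis compound 3 is estimated at 1500 nM, with a range from 500 nM to 5000 nM.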

Compound 3, half-maximal inhibitory concentration: 2000 nM
Beside the measured number, compound 3's estimate is 1.3-fold (0.12 log units) below it; the measured number falls inside the stated range.
By their numbers in this assay, from the lowest: compounds 2, 3 and 1 (each within the scatter of the next, the first and the last beyond it).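

In this assay the exchange of ethoxy for methyl, para to a large group, gives a 1.8-fold higher number from compound 2 to compound 3 (0.26 log units; within the scatter) and is the first change shown that touches only this substituent, so at this position the loss of two heavy atoms and the one hydrogen-bond acceptor is not resolved from the scatter. The other new comparison, 4-methylphenyl in place of 3-methoxybenzyl, gives a 1.3-fold lower number from compound 1 to compound 3 (0.10 log units; within the scatter), which leaves compound 3 separated from neither neighbour, even though a 2.3-fold lower number from compound 1 to compound 2 (0.36 log units; beyond the scatter) lies beyond the scatter. Nothing at hand accounts for these numbers.

On these data alone, whether this position tolerates groups of a different kind stays open, for instance an amine, a carboxylic acid or a longer chain such as butoxy, since ethoxy and methyl are the only two substituents compared here on the directly attached phenyl ring. As far as these compounds go, whether the small size of the ethoxy-to-methyl step would hold on a core or warhead other than the one shared by these bromoacrylamides also stays open.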